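Amine variation at the benzylic position of the shared core

The compounds below may be only part of what the source reports. "The series", "measured", "known", "first", "only" and "open" are said of these compounds alone.

Compound 1 `COc1cc(OC)c(C(=O)/C=C/c2ccccc2Cl)c(O)c1CN1CCCC1` gives 14200 nM in a functional assay on HL-60 cells (Homo sapiens) for antiproliferative activity, with a stated time of 72 h (on this read-out higher numbers stand for weaker inhibition and lower numbers for stronger inhibition), and stands highest of the two numbers measured. Within the data shown here, compound 2 `COc1cc(OC)c(C(=O)/C=C/c2ccccc2Cl)c(O)c1CN(C)CCCN(C)C` gives 11400 nM in this assay; the only measured step, a 1.2-fold lower number from compound 1 to compound 2 (0.10 log units; within the scatter), swaps the amine at the same place and stays within the scatter. Compound 3 `COc1cc(OC)c(C(=O)/C=C/c2ccccc2Cl)c(O)c1CN(C)C` differs from compound 1 by dimethylamino in place of pyrrolidin-1-yl on a saturated chain carbon bound to an aromatic carbon. Among the measured compounds shown here, since the one comparable step is flat, no step beyond the scatter is expected in this assay. The estimate for compound 3 is 14000 nM, with a range from 5000 nM to 40000 nM. The expected step is therefore a 1.0-fold lower number from compound 1 to compound 3 (0.01 log units; within the scatter).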

Compound 3, half-maximal inhibitory concentration: 19200 nM
Compound 3: the middle estimate sits 1.4-fold (0.14 log units) below what was measured, and the stated range covers the measured number.
By their numbers in this assay, from the lowest: compounds 2, 1 and 3 (each within the scatter of the next).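

Dimethylamino in place of pyrrolidin-1-yl on a saturated chain carbon bound to an aromatic carbon stays within the scatter in this assay (a 1.4-fold higher number from compound 1 to compound 3 (0.13 log units; within the scatter)), so the ring of compound 1 makes no measurable difference here. Hydrogen in place of 2-(dimethylamino)ethyl on a saturated chain carbon bound to an amine nitrogen also stays within the scatter (a 1.7-fold higher number from compound 2 to compound 3 (0.23 log units; within the scatter)), so the second amine of compound 2 adds nothing measurable either. No available data explain this flatness.

All three compounds carry a tertiary amine at this position. On these data alone, whether a morpholine, a primary amine or a carboxylic acid there would shift the number remains open.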